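Aryl Sulfonyl Exchange on a Shared Core

A few compounds are considered here, and "the series" means these few. Any claim that something is new, unique, unknown or untested is made for them only; others in the source may bear on it.

compound 1, `Cc1cc(C)c(S(=O)(=O)NC2=NCCN2C(=S)SN2CCn3c2nsc3=S)c(C)c1`: >= 20000 nM
compound 2, `COc1cc(C)ccc1S(=O)(=O)NC1=NCCN1C(=S)SN1CCn2c1nsc2=S`: >= 20000 nM

Compound 1 `Cc1cc(C)c(S(=O)(=O)NC2=NCCN2C(=S)SN2CCn3c2nsc3=S)c(C)c1` was tested in a functional assay on KYSE-510 cells (Homo sapiens) for antiproliferative activity, read by crystal violet staining, with a stated time of 96 h; on this read-out lower numbers stand for stronger inhibition of growth and higher numbers for weaker inhibition of growth. In this assay compound 1 gives >= 20000 nM, which is a limit of the assay and not a number. Compound 2 `COc1cc(C)ccc1S(=O)(=O)NC1=NCCN1C(=S)SN1CCn2c1nsc2=S` gives >= 20000 nM in this assay, again a limit rather than a number. Within the data shown here, the step that the two limits leave unreadable from compound 1 to compound 2 therefore cannot be read because of the limit of >= 20000 nM in this assay, at which 2 of the 2 values shown sit, and the study so far offers no step with a readable size.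

Compound 3 `COc1ccc(S(=O)(=O)NC2=NCCN2C(=S)SN2CCn3c2nsc3=S)cc1` is the next member. The change from compound 1 is 4-methoxyphenyl in place of 2,4,6-trimethylphenyl on a sulfonyl sulfur. Among the measured compounds shown here, the only measured step that touches the same place is the unreadable one, so no measured step bears on this change with a size; what the two limits show is that both compound 1 and compound 2 sit at the edge of the assay, and nothing suggests compound 3 will leave it.

Compound 3 is therefore expected to give about 20000 nM in this assay, most likely reported as a limit, within an estimated range of 10000 nM to 40000 nM. The expected step is a number no higher from compound 1 to compound 3 (the limit leaves the size open), which is estimated to be none beyond the scatter.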

Compound 3, concentration for 50% growth inhibition: >= 20000 nM
Compound 3 ended at the assay's limit (the forecaster's own chance of this, stated with the estimate: 85%); the middle value lies on the limit itself.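

In this assay compound 3 gives >= 20000 nM, which is a limit of the assay and not a number. Neither the step from compound 1 to compound 3 nor the step from compound 2 to compound 3 can be read: the limit of >= 20000 nM in this assay, at which 3 of the 3 values shown sit.

The compounds shown leave open what the true values of compound 1, compound 2 and compound 3 are, and whether any group on the sulfonyl sulfur of the shared core would give a readable value.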